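Replacing one group of compound 3

The compounds below may be only part of what the source reports. "The series", "measured", "known", "first", "only" and "open" are said of these compounds alone.

Compound 1 `NCCCCN(C[C@H]1Cc2cccnc2CN1)[C@H]1CCCc2cccnc21`: 2 nm/s
Compound 2 `CN(C[C@@H]1Cc2ncccc2CN1)[C@H]1CCCc2cccnc21`: 230 nm/s
Compound 3 `NC(=O)NC/C=C\CN(C[C@H]1Cc2ncccc2CN1)[C@H]1CCCc2cccnc21`: 5 nm/s

All three values come from an ADME assay for permeability, using PAMPA, with a stated time of 4 h, at pH 5.5 (a higher number here means that the compound crosses the layer faster, a lower number that the compound crosses the layer more slowly), and compound 3 stands second highest among them, above compound 1 and far below compound 2. Compound 4 `c1cnc2c(c1)CN[C@@H](CN(CCCCNC1COC1)[C@H]1CCCc3cccnc31)C2` differs from compound 3 by a group of 8 heavy atoms (6 carbon, 1 nitrogen, 1 oxygen; one four-membered non-aromatic ring with 1 hetero atom) in place of a group of 7 heavy atoms (4 carbon, 2 nitrogen, 1 oxygen; no ring), on a saturated chain carbon bound to an amine nitrogen and has not yet been measured. Among the measured compounds shown here, no measured pair isolates this change, so only the values can guide expectation. Compound 1 at 2 nm/s and compound 3 at 5 nm/s both carry a long chain, and both lie well below compound 2 at 230 nm/s in this assay while compound 4 keeps a long chain too. The expected step is small and upward, a 1.6-fold higher number from compound 3 to compound 4 (0.20 log units; within the scatter) and probably not beyond the scatter. The expected value of compound 4 is 8 nm/s with an estimated range from 2 nm/s to 35 nm/s in this measurement.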

Compound 4, apparent permeability: 7 nm/s
For compound 4 the middle estimate is 1.1-fold (0.06 log units) above the measured one; the range from low to high includes it.
By their numbers in this assay, from the lowest: compound 1; then compounds 3 and 4 (each within the scatter of the next); then compound 2.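

Placing the group of 8 heavy atoms with one four-membered non-aromatic ring with 1 hetero atom on a saturated chain carbon bound to an amine nitrogen, instead of the group of 7 heavy atoms with no ring, gives a 1.4-fold higher number from compound 3 to compound 4 (0.15 log units; within the scatter) in this assay. This first step readable at this place shows that these two groups, despite their different counts of donors and acceptors, cannot be told apart here. Nothing measured bears on the reason for this result.

As far as these compounds go, whether a carboxylic acid or a morpholine at this place would also stay within the scatter remains open. So does the effect of a shorter chain.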